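The source may hold more compounds than are shown below. What is called first, only, known or untested is meant among the compounds shown, and "the series" means these compounds.

Measured compounds:
- compound 1, `Cc1cc(-c2ccccc2)n(-c2nc(C(F)(F)F)cc(=O)[nH]2)n1`: > 50000 nM in an ADME assay on CHO cells (Cricetulus griseus) for cytotoxicity, read by MTT assay; on this read-out higher numbers stand for weaker inhibition and lower numbers for stronger inhibition
- compound 2, `Cc1cc(N)n(-c2nc(C(F)(F)F)cc(=O)[nH]2)n1`: compound 2 gives 120000 nM.

For compound 1 the value in this assay is a limit of the assay, not a number. Compound 2 therefore carries the only number shown; the one further value is a limit. The step that the limit leaves unreadable from compound 1 to compound 2 stays unreadable, because of the limit of > 50000 nM in this assay, at which 1 of the 2 values shown sits.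

Compound 3, `CCOc1cc(C)nn1-c1nc(C(F)(F)F)cc(=O)[nH]1`, is not yet measured. It differs from compound 2 by ethoxy in place of amino on an aromatic carbon. For the measured compounds named here, no measured step bears on this change in a readable way: the only step in this assay, from compound 1 to compound 2, gives no size. The expectation for compound 3 therefore rests on compound 2 alone, with its 120000 nM, and no direction is assumed beyond the scatter.

Compound 3 is estimated at 100000 nM, with a range of 35000 nM to 300000 nM. The step this estimate means, a 1.2-fold lower number from compound 2 to compound 3 (0.08 log units; within the scatter), is expected to stay within the scatter.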

Compound 3, half-maximal inhibitory concentration: > 50000 nM
Compound 3 ended at the assay's limit; the forecaster's own chance of this, stated with the estimate: 50%; the middle value lies beyond the limit too.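

The steps from compound 2 to compound 3 and from compound 1 to compound 3 cannot be read in this assay: the limit of > 50000 nM in this assay, at which 2 of the 3 values shown sit.

The compounds shown leave open whether compound 1 or compound 3, with phenyl or ethoxy in place of amino, differs from compound 2 at all in this assay.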